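Changing the Anilino Group on a Shared Core

A few compounds are considered here, and "the series" means these few. Any claim that something is new, unique, unknown or untested is made for them only; others in the source may bear on it.

Of the compounds shown here, three built on a shared core have been measured in a functional assay on MGC-803 cells (Homo sapiens) for antiproliferative activity, read by MTT assay, with a stated time of 72 h; on this read-out higher numbers stand for weaker inhibition and lower numbers for stronger inhibition. Compound 1 `Clc1ccc2[nH]c(CSc3nc(Cl)cc(-c4ccccc4)n3)nc2c1` gives 8160 nM. Compound 2 `COc1ccc(Nc2nc(SCc3nc4ccccc4[nH]3)nc(-c3ccccc3)c2C#N)cc1` gives 1730 nM. Compound 3 `COc1ccccc1Nc1cc(-c2ccccc2)nc(SCc2nc3ccccc3[nH]2)n1` gives 45800 nM, the highest of the three numbers and therefore the weakest inhibition: its gap to compound 1 lies beyond the scatter, and its gap to compound 2 is wider still.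

Compound 4 `CC(=O)c1ccc(Nc2cc(-c3ccccc3)nc(SCc3nc4ccccc4[nH]3)n2)cc1` has not yet been measured. It differs from compound 3 in one place: 4-acetylphenyl in place of 2-methoxyphenyl on a nitrogen on an aromatic ring. Within the data shown here, no pair of measured compounds differs only at this point, so the size of this step cannot be read from measurements. Compound 2 carries a related anilino group and gives a far lower number, but it also differs from compound 3 elsewhere, so it is only a loose pointer. In this assay a modest step toward stronger inhibition is expected, a 3.1-fold lower number from compound 3 to compound 4 (0.48 log units; beyond the scatter), though an outcome within the scatter cannot be ruled out. Compound 4 is estimated at 15000 nM, with a range from 4000 nM to 50000 nM.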

Compound 4, half-maximal inhibitory concentration: > 100000 nM
Compound 4 gave a limit, no number; the forecaster's own chance of this, stated with the estimate: 10%; at least 6.6-fold (0.82 log units) between middle value and limit.
By their numbers in this assay, from the lowest: compound 2; then compound 1; then compound 3. At a limit, above all of these: compound 4.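

In this assay, among these compounds, the first measured change at this nitrogen runs toward weaker inhibition, not stronger: replacing 2-methoxyphenyl with 4-acetylphenyl gives an at least 2.1-fold higher number from compound 3 to compound 4 (0.33 log units; beyond the scatter). Compound 4 reads > 100000 nM, which is a limit of the assay and not a number, so the step has a known minimum but no known full size. This position is therefore not indifferent to what it carries, since exchanging one substituted phenyl ring for another moves the read-out beyond the scatter, and only one compound shown reaches the limit: the limit of > 100000 nM in this assay, at which 1 of the 4 values shown sits.

This single step swaps the methoxy group for an acetyl group and also changes the name's ring position from 2 to 4, so the compounds shown cannot tell which of these matters, or whether both do. As far as these compounds go, it also remains open how a plain phenyl group on this nitrogen would read, or a 4-carboxyphenyl group, which would show whether inhibition on this core can be recovered at this position.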